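Isobutyl Carbamate Selenocyanate: Expected Growth Inhibition

The compounds below may be only part of what the source reports. "The series", "measured", "known", "first", "only" and "open" are said of these compounds alone.

Compound 1 `CC(C)COC(=O)Nc1ccc([Se][Se]c2ccc(NC(=O)OCC(C)C)cc2)cc1`: 48600 nM
Compound 2 `CCCOC(=O)Nc1ccc([Se]C#N)cc1`: 51900 nM
Compound 3 `CCOC(=O)Nc1ccc([Se][Se]c2ccc(NC(=O)OCC)cc2)cc1`: 51100 nM

In a functional assay on HT-29 cells (Homo sapiens) for cytotoxicity, read by MTT assay, with a stated time of 72 h (on this read-out lower numbers stand for stronger inhibition of growth and higher numbers for weaker inhibition of growth), compound 2 gives 51900 nM and stands at the top of the three numbers, yet the gaps to compound 3 and to compound 1 are within the scatter, so the three cannot be told apart. Compound 4 `CC(C)COC(=O)Nc1ccc([Se]C#N)cc1` is the next compound to be measured. It differs from compound 2 by methyl in place of hydrogen on a saturated chain carbon bound to two saturated chain carbons. For the measured compounds named here, no pair of measured compounds shows the effect of this change on its own, and the three measured compounds, with propyl, ethyl and isobutyl carbamates, give numbers that do not separate. The step of a 1.0-fold higher number from compound 2 to compound 4 (0.00 log units; within the scatter) is therefore expected to stay within the scatter. Compound 4 is estimated at 52000 nM, with a range from 25000 nM to 110000 nM.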

Compound 4, concentration for total growth inhibition: 31300 nM
Beside the measured number, compound 4's estimate is 1.7-fold (0.22 log units) above it, within the range that was stated.
By their numbers in this assay, from the lowest: compounds 4, 1, 3 and 2 (each within the scatter of the next).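

Propyl to isobutyl gives a 1.7-fold lower number from compound 2 to compound 4 (0.22 log units; within the scatter) in this assay and is the first comparison in which only this chain carbon differs. Methyl in place of hydrogen at this place therefore leaves compound 4 indistinguishable from compound 2 on this read-out, so this single branch does not measurably alter growth inhibition. No measurement shown offers an explanation for the step. Still open, as far as these compounds go, is whether a longer chain, such as hexyl, or an amine or a carboxylic acid at this chain carbon would move the number beyond the scatter.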